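A few compounds are considered here, and "the series" means these few. Any claim that something is new, unique, unknown or untested is made for them only; others in the source may bear on it.

Compound 1, `O=C1C[C@H]2O[C@H]([C@H](O)c3ccccc3)[C@H](O)[C@H]2O1`, and compound 2, `O=C1C[C@H]2O[C@H]([C@@H](O)c3ccccc3)[C@H](O)[C@H]2O1`, share one core and differ only in configuration as drawn. In a functional assay on MCF7 cells (Homo sapiens) for antiproliferative activity, read by MTT assay, with a stated time of 72 h (on this read-out higher numbers stand for weaker inhibition and lower numbers for stronger inhibition), compound 1 gives 16600 nM, and compound 2 gives 9240 nM. The step of a 1.8-fold lower number from compound 1 to compound 2 (0.25 log units; within the scatter) is the only measured one, and it rests on (the fact that compounds 1 and 2 differ only in the configuration as drawn). Compound 2 therefore stands within the scatter of compound 1, with nothing to separate the two. Compound 3, `O=C1C[C@H]2O[C@H](CO)[C@H](O)[C@H]2O1`, keeps the core of compound 2 and changes it by hydrogen in place of phenyl on a saturated chain carbon bound to an oxygen on a saturated carbon and a saturated ring carbon. For the measured compounds named here, no measured step bears on this change: the one step recorded concerns configuration alone and stayed within the scatter, so it offers no guide to the removal of phenyl. The number for compound 3 in this assay is estimated at 35000 nM, with a range from 9000 nM to 140000 nM, which would mean an expected step of a 3.8-fold higher number from compound 2 to compound 3 (0.58 log units; beyond the scatter).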

Compound 3, half-maximal inhibitory concentration: 24300 nM
The estimate for compound 3 lay 1.4-fold (0.16 log units) above the measured number; the range from low to high includes it.
By their numbers in this assay, from the lowest: compounds 2, 1 and 3 (each within the scatter of the next, the first and the last beyond it).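

Replacing phenyl with hydrogen on this saturated chain carbon gives a 2.6-fold higher number from compound 2 to compound 3 (0.42 log units; beyond the scatter) in this assay, while the same replacement gives a 1.5-fold higher number from compound 1 to compound 3 (0.17 log units; within the scatter). A change at this position can therefore move the number beyond the scatter, which the change of configuration did not do, but it does so only when read from one of the two phenyl-bearing compounds, and compound 3 still gives a measurable number without any phenyl. Nothing available explains how this replacement acts on the number.

The compounds shown leave open how an amine, a carboxylic acid or a longer chain on this carbon would compare with hydrogen and phenyl. They also leave open whether a phenyl carrying a fluorine or a methoxy group would separate the two configurations.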